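Replacing Pyridin-2-yl with Hydroxymethyl: Expected Tolerance

The source may report more compounds than this note shows. Statements on the series, on what has been measured and on what is new or still open speak of the compounds shown alone.

Compound 1, `Cn1c([N+](=O)[O-])cnc1C(=O)NCc1ccccn1`, was tested in a toxicity assay on HepG2 cells (Homo sapiens) for inhibition, read by resazurin assay, with a stated time of 24 h; a higher number here means that more compound is tolerated, a lower number that less compound is tolerated. In this assay compound 1 gives > 100000 nM, which is a limit of the assay and not a number. Compound 2, `O=C(NCc1ccccn1)c1ncc([N+](=O)[O-])[nH]1`, differs from it by a hydrogen in place of methyl on an aromatic nitrogen. In this assay compound 2 gives > 100000 nM, again a limit rather than a number. The step that the two limits leave unreadable from compound 1 to compound 2 cannot be read because of the limit of > 100000 nM in this assay, at which 2 of the 2 values shown sit. Compound 2 therefore stands only at a limit on the values shown. Compound 3, `O=C(NCCO)c1ncc([N+](=O)[O-])[nH]1`, carries the change (hydroxymethyl in place of pyridin-2-yl on a saturated chain carbon bound to an amide-type nitrogen). For the measured compounds named here, no measured step bears on this change, and the single known step is itself unreadable. The expectation for compound 3 is thus no step beyond the scatter, with a number no higher from compound 2 to compound 3 (the limit leaves the size open) as the estimated step. Compound 3 is expected to give 100000 nM, within 40000 nM to 300000 nM.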

Compound 3, half-maximal cytotoxic concentration: > 100000 nM
Compound 3 gave a limit, no number (the forecaster's own chance of this, stated with the estimate: 85%); the middle value lies on the limit itself.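

No step can be read from compound 2 to compound 3 in this assay, because both results are limits and not numbers: the limit of > 100000 nM in this assay, at which 3 of the 3 values shown sit. The compounds shown leave open how much of any of them is tolerated and whether hydroxymethyl in place of pyridin-2-yl changes that.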